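The compounds below may be only part of what the source reports. "The series", "measured", "known", "first", "only" and "open" are said of these compounds alone.

Compound 1 `COc1ccc(CN(C(=O)C2CC2)c2cc(OC)c(OC)c(OC)c2)cc1O` shows the lowest number of the three measured compounds in a functional assay on KYSE-450 cells (Homo sapiens) for inhibition, read by MTT assay, with a stated time of 48 h (on this read-out higher numbers stand for weaker inhibition and lower numbers for stronger inhibition), where compound 1 gives 80 nM. The other two measured compounds lie far beyond the usual scatter from it. In this assay compound 3 `C/C=C/C(=O)N(Cc1ccc(OC)c(Cl)c1)c1cc(OC)c(OC)c(OC)c1` gives 10100 nM, and in this assay compound 2 `COc1ccc(CNc2cc(OC)c(OC)c(OC)c2)cc1F` gives 46200 nM. Among the measured compounds shown here, neither of these two differs from compound 1 in a single place, so their values say only that compound 1 is the strongest inhibitor of the three on this read-out, with both compound 3 and compound 2 clearly weaker.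

Compound 4 `COc1ccc(CN(C(=O)/C=C/CBr)c2cc(OC)c(OC)c(OC)c2)cc1O` has not yet been measured. It differs from compound 1 in one place: 3-bromoprop-1-en-1-yl in place of cyclopropyl on a carbonyl carbon. For the measured compounds named here, no step between measured compounds isolates a change at the carbonyl carbon, so there is no measured step to lean on for this move.

Since compound 1 holds the low value of 80 nM and compound 4 keeps the rest of the structure, a moderate loss beyond the scatter is expected, with the step from compound 1 to compound 4 estimated as a 3.1-fold higher number from compound 1 to compound 4 (0.49 log units; beyond the scatter). Compound 4 is therefore expected to give about 250 nM in this assay, within a range from 50 nM to 2000 nM.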

Compound 4, half-maximal inhibitory concentration: 100 nM
Compound 4: the middle estimate sits 2.5-fold (0.40 log units) above what was measured; the range from low to high includes it.
By their numbers in this assay, from the lowest: compounds 1 and 4 (each within the scatter of the next); then compound 3; then compound 2.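

Among the compounds shown here, at this position, on a carbonyl carbon whose other neighbour is the amide-type nitrogen, the exchange gives the first measured step in this assay, a 1.3-fold higher number from compound 1 to compound 4 (0.10 log units; within the scatter), so the read-out does not tell cyclopropyl and 3-bromoprop-1-en-1-yl apart. With the rest of the structure held fixed, the three-membered non-aromatic ring of carbon only gives way to an open group with no ring, one double bond outside aromatic rings and a bromine, and compound 4 gives 100 nM in the same low range as compound 1, so in this pair the ring is not needed for a low number. Nothing in the material at hand bears on why these two groups read alike.

The compounds shown leave open how much the double bond and the bromine each count, which a plain propyl group or the same unsaturated chain ending in a dimethylamino group instead of bromine would separate. They also leave open whether a longer chain or a carboxylic acid at the end of the chain would be tolerated at this position, and whether the match between these two groups holds in other cell lines.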